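Benzyl halogen change from compound 1 to compound 4

The source may report more compounds than this note shows. Statements on the series, on what has been measured and on what is new or still open speak of the compounds shown alone.

Measured so far:
compound 1 `O=C1/C(=C/c2ccccc2F)CN(Cc2cn(Cc3ccc(F)cc3)nn2)C/C1=C\c1ccccc1F`, 6400 nM
compound 2 `Cc1ccc(/C=C2\CN(C(=S)SCc3cn(Cc4ccccc4Cl)nn3)C/C(=C\c3ccc(C)cc3)C2=O)cc1`, 49300 nM
compound 3 `COc1ccc(/C=C2\CN(Cc3cn(Cc4ccc(F)cc4)nn3)C/C(=C\c3ccc(OC)cc3)C2=O)cc1`, 49300 nM

In a functional assay on 4T1 cells (Mus musculus) for cytotoxicity, read by MTT assay, with a stated time of 24 h (a lower number here means a stronger inhibitor, a higher number a weaker inhibitor), compound 1 gives 6400 nM, the lowest of the three numbers; compound 2 and compound 3 each sit higher by a gap beyond the scatter, and these two cannot be ordered against each other. Among the compounds with values here, no pair of measured compounds differs in one place, so no single-change step is known.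

Compound 4 `O=C1/C(=C/c2ccccc2F)CN(Cc2cn(Cc3cccc(Cl)c3)nn2)C/C1=C\c1ccccc1F` differs from compound 1 in one place: 3-chlorophenyl in place of 4-fluorophenyl on a saturated chain carbon bound to an aromatic nitrogen. Nothing measured here tests such a change, so the step in this assay is expected to be small, not beyond the scatter, with no clear direction. Compound 4 is therefore expected to give 7000 nM, in the range 2500 nM to 20000 nM. This expectation amounts to a 1.1-fold higher number from compound 1 to compound 4 (0.04 log units; within the scatter).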

Compound 4, half-maximal inhibitory concentration: 6100 nM
Estimate against measurement, compound 4: 1.1-fold (0.06 log units) above; low and high end bracket the measured number.
By their numbers in this assay, from the lowest: compounds 4 and 1 (each within the scatter of the next); then compounds 2 and 3 (each within the scatter of the next).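

In this assay, within the data shown here, the first single-change step reads a 1.0-fold lower number from compound 1 to compound 4 (0.02 log units; within the scatter) for 3-chlorophenyl in place of 4-fluorophenyl. At this place, on a saturated chain carbon bound to an aromatic nitrogen, the change from 4-fluorobenzyl to 3-chlorobenzyl therefore leaves no readable difference on the core of compound 1. No available measurement offers an explanation for this result. Open, going by these compounds, is how a carboxylic acid, an amine or a longer chain on the phenyl ring would read at this place. Also open, on these data alone, is whether the same change reads alike on the core of compound 3.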